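The compounds below may be only part of what the source reports. "The series", "measured", "known", "first", "only" and "open" are said of these compounds alone.

Working notes on the series. Measured so far in an assay on isolated protein for inhibition of cathepsin S (Homo sapiens); a higher number here means a weaker inhibitor, a lower number a stronger inhibitor:

compound 1, `CC(=O)N1CCc2c(c(-c3ccc(Br)cc3)nn2CC(O)CN2CCC(n3c(O)nc4ccc(Cl)cc43)CC2)C1`; compound 1 gives 120 nM
compound 2, `CC(=O)N1CCc2c(c(-c3ccc(Br)cc3)nn2CC(O)CN2CCC(n3c(O)nc4cc(Cl)c(Cl)cc43)CC2)C1`; compound 2 gives 110 nM
compound 3, `CS(=O)(=O)N1CCc2c(c(-c3ccc(C(F)(F)F)cc3)nn2CC(O)CN2CCC(n3c(O)nc4ccccc43)CC2)C1`; compound 3 gives 50 nM

Compound 1 and compound 2 share one core, while compound 3 is built on another; the difference between the two cores is not broken down here. Of the three numbers, that of compound 3 is the lowest, and its gaps to compound 1 and to compound 2 both lie beyond the usual scatter.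

One single-point step is measured within the set: a 1.1-fold lower number from compound 1 to compound 2 (0.04 log units; within the scatter), the change being (chloro in place of hydrogen on an aromatic carbon). Compound 4, `CS(=O)(=O)N1CCc2c(c(-c3ccc(C(F)(F)F)cc3)nn2CC(O)CN2CCC(n3c(O)nc4ccc(Cl)cc43)CC2)C1`, has not yet been measured. Its relation to compound 3 is chloro in place of hydrogen on an aromatic carbon. Among the measured compounds shown here, this is the same kind of change as the one from compound 1 to compound 2, but not the same: in the step from compound 1 to compound 2 the entering chloro sits ortho to a chloro group, whereas in compound 4 no such neighbouring group is present at the place of the change.

For the measured compounds named here, with only one measured instance to go on, the expectation for compound 4 rests on the step in compound 1 to compound 2, a 1.1-fold lower number from compound 1 to compound 2 (0.04 log units; within the scatter), which sits within the scatter. The step from compound 3 to compound 4 is therefore expected to be a 1.1-fold lower number from compound 3 to compound 4 (0.05 log units; within the scatter), again within the scatter. Compound 4 is estimated at 45 nM, with a likely range from 22 nM to 90 nM.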

Compound 4, half-maximal inhibitory concentration: 60 nM
Beside the measured number, compound 4's estimate is 1.3-fold (0.12 log units) below it, within the range that was stated.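

In this assay the new step reads a 1.2-fold higher number from compound 3 to compound 4 (0.08 log units; within the scatter), so the chloro leaves the number within the scatter on the core of compound 3, as it does on the core of compound 1, and the two steps agree: the same change on two cores in this assay, a 1.1-fold lower number (0.04 log units; within the scatter) from compound 1 to compound 2 and a 1.2-fold higher number (0.08 log units; within the scatter) from compound 3 to compound 4, 1.3-fold (0.12 log units) apart, within the scatter of two such steps Within this series, then, the change carries from one core to the other as a step too small to read, and the core of compound 3 gives no sign of a different outcome. This does not show that the chloro is without consequence in general: there are only two instances, one in which the chloro enters a ring already carrying a chloro and one in which it enters an otherwise unsubstituted ring, and a single assay cannot say how the change would behave on any further core.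

Still open, as far as these compounds go, is whether a different group at the same place, such as methoxy, a nitrile or an amine, would give a step beyond the scatter where chloro does not. Also open, from the compounds shown here alone, is whether a second chloro on the 6-chloro-2-hydroxy-1H-benzimidazol-1-yl group of compound 4 would behave as it does in compound 2.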